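Adding a second trifluoromethyl to an amide-linked aryl

The source may report more compounds than this note shows. Statements on the series, on what has been measured and on what is new or still open speak of the compounds shown alone.

Two compounds have been measured so far:
compound 1, `COc1cc(Cl)cc(-c2nn(-c3cccc(NC(=O)Nc4ccc(Cl)c(C(F)(F)F)c4)c3)cc2-c2ccncc2)c1`, giving 5.2%;
compound 2, `COc1cc(Cl)cc(-c2nn(-c3cccc(NC(=O)c4cccc(C(F)(F)F)c4)c3)cc2-c2ccncc2)c1`, giving 39.1%.

Both were tested in a functional assay on A549 cells (Homo sapiens) for inhibition, read by sulforhodamine B assay, with a stated time of 48 h, tested at 10 uM; on this read-out higher numbers stand for a weaker effect at the one concentration tested and lower numbers for a stronger effect. Compound 2 stands highest of the two numbers, meaning its effect at the one concentration is the weaker of the pair. Within the data shown here, the only measured step, a number 33.9 percentage points higher from compound 1 to compound 2 (beyond the scatter), is the exchange of a (4-chloro-3-(trifluoromethyl)phenyl)amino group for a 3-(trifluoromethyl)phenyl group on a carbonyl carbon, and it lifted the read-out sharply.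

Compound 3, `COc1cc(Cl)cc(-c2nn(-c3cccc(NC(=O)c4cc(C(F)(F)F)cc(C(F)(F)F)c4)c3)cc2-c2ccncc2)c1`, has not yet been measured. It differs from compound 2 in one place: trifluoromethyl in place of hydrogen on an aromatic carbon. Among the measured compounds shown here, no measured step bears on this kind of change; the single known step concerns a different part of the molecule and says nothing about a second trifluoromethyl group on the same ring. With that gap, the expected step of a number 4.1 percentage points lower from compound 2 to compound 3 (within the scatter) is none beyond the scatter, so compound 3 is expected to sit near compound 2. Compound 3 is therefore estimated at 35%, with a range from 12% to 60%.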

Compound 3, a percentage reported as activity, at one concentration (the size of the read-out at that concentration, not a potency): 43.5%
Beside the measured number, compound 3's estimate is 8.5 percentage points below it; low and high end bracket the measured number.
By their numbers in this assay, from the lowest: compound 1; then compounds 2 and 3 (each within the scatter of the next).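

In this assay, a trifluoromethyl in place of hydrogen on an aromatic carbon, meta to a large group and meta to the trifluoromethyl group already on that ring, gives a number 4.4 percentage points higher from compound 2 to compound 3 (within the scatter). This position therefore accepts a group of four heavy atoms without a shift that can be told apart from ordinary repeat variation, while the change on the carbonyl carbon, a number 33.9 percentage points higher from compound 1 to compound 2 (beyond the scatter), remains the only step beyond the scatter among these compounds. No measurement available here explains why adding this group leaves the read-out in place.

Among these compounds, whether an amine or a carboxylic acid at this same ring position would also leave the read-out in place remains open, since a trifluoromethyl is only one kind of group and says little about others. Also open, as far as these compounds go, is whether the same added trifluoromethyl would have so little effect on compound 1, which gives 5.2%, and whether these results at a single concentration would hold across a range of concentrations.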